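A few compounds are considered here, and "the series" means these few. Any claim that something is new, unique, unknown or untested is made for them only; others in the source may bear on it.

Compound 1, `CN1CCC(c2c[nH]c3cnc(NC(=O)c4ccc(F)cc4)cc23)CC1`: 80 nM
Compound 2, `CCCCCCCC(=O)Nc1ccc2[nH]cc(C3CCN(C)CC3)c2n1`: 32 nM

Both compounds were tested in an assay for binding affinity to 5-hydroxytryptamine receptor 1B (Homo sapiens), read by radioligand binding; a lower number here means a stronger inhibitor, a higher number a weaker inhibitor. Of the two numbers, compound 2 has the lower one, and its gap to compound 1 lies beyond the usual scatter of repeated measurements, so compound 2 is the stronger binder of this pair.

Compound 3, `CN1CCC(c2c[nH]c3ccc(NC(=O)C4CC4)nc23)CC1`, has not yet been measured. It differs from compound 2 in one place: cyclopropyl in place of heptyl on a carbonyl carbon. For the measured compounds named here, no pair of measured compounds shows this kind of change, so there is nothing in the data that tells how exchanging the heptyl for the cyclopropyl plays out here; the expectation rests only on the two measured values and the size of the change.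

In this assay compound 3 is expected to give a somewhat higher number, a modest step beyond the scatter rather than a large one. The estimated step is a 3.1-fold higher number from compound 2 to compound 3 (0.49 log units; beyond the scatter). For compound 3 the expected value is 100 nM, with a range from 25 nM to 400 nM.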

Compound 3, inhibition constant: 1700 nM
For compound 3 the middle estimate is 17-fold (1.23 log units) below the measured one, and the stated range ends below it.
By their numbers in this assay, from the lowest: compound 2; then compound 1; then compound 3.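

Swapping heptyl for cyclopropyl on a carbonyl carbon in this assay gives a 53-fold higher number from compound 2 to compound 3 (1.73 log units; beyond the scatter), a large step and well beyond the usual scatter, so binding at this receptor is far from indifferent to what sits at this position. The change replaces an open chain of 7 carbons with a three-membered ring of 3 carbons, and neither group carries a hydrogen-bond donor, a hydrogen-bond acceptor or a net charge, so the computed differences here are only the carbon count and the ring. No supporting measurement bears on this result, so the reason for the step remains unknown.

Because the carbon count and the ring change together in this single step, these compounds cannot show which of the two matters, and a straight propyl chain on the same carbonyl carbon would help to separate them. From the compounds shown here alone, it also remains open how binding would respond to a chain longer than heptyl, or to a heptyl chain ending in an amine or a carboxylic acid.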